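This account rests on a few compounds, and the source may have more. Where it says the series, first, only, none or still open, it means among the compounds named here.

Of the compounds shown here, three built on one shared core have been tested in a functional assay on NCI-H460 cells (Homo sapiens) for antiproliferative activity, read by CCK-8 assay, with a stated time of 72 h, tested at 8 uM; on this read-out higher numbers stand for a stronger effect at the one concentration tested and lower numbers for a weaker effect. Compound 1 `CN1CCN(c2nc(Cl)nc3c2ncn3Cc2ccc(C(=O)Nc3ccccc3N)cc2)CC1` gives 55.1% there, compound 2 `Nc1ccccc1NC(=O)/C=C/c1ccc(Cn2cnc3c(NCc4ccccc4)nc(Cl)nc32)cc1` gives 49.1%, and compound 3 `Nc1ccccc1NC(=O)c1ccc(Cn2cnc3c(Nc4ccc(-c5ccccn5)cc4)nc(Cl)nc32)cc1` gives 30.8%. Compound 3 thus stands lowest of the three numbers: its nearest neighbour is compound 2, whose number is higher by more than the usual scatter, and compound 1 lies further above it, again beyond the scatter.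

The next compound, compound 4 `Nc1ccccc1NC(=O)c1ccc(Cn2cnc3c(NCc4ccccc4)nc(Cl)nc32)cc1`, has not yet been measured in this assay. It differs from compound 3 in a single place: benzyl in place of 4-(pyridin-2-yl)phenyl on a nitrogen on an aromatic ring.

Among the compounds with values here, no pair of measured compounds differs in just this group, so the size of the step in this assay cannot be read off directly. Compound 2, which also carries a benzyl group on a nitrogen on an aromatic ring, gives 49.1%, and that points to a step upward from compound 3 rather than downward. An upward step of moderate size, beyond the scatter, is expected, as a number 14.2 percentage points higher from compound 3 to compound 4 (beyond the scatter) expresses. Compound 4 is therefore estimated at 45%, with a range from 30% to 60%.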

Compound 4, a percentage reported as inhibition, at one concentration (the size of the read-out at that concentration, not a potency): 61.2%
For compound 4 the middle estimate is 16.2 percentage points below the measured one; the whole stated range lies below it.
By their numbers in this assay, from the lowest: compound 3; then compounds 2, 1 and 4 (each within the scatter of the next, the first and the last beyond it).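

In this assay, benzyl in place of 4-(pyridin-2-yl)phenyl on a nitrogen on an aromatic ring gives a number 30.4 percentage points higher from compound 3 to compound 4 (beyond the scatter), a large step, so the group at this place clearly affects the read-out and the smaller, single-ring benzyl comes out ahead of the two-ring group. Two other single changes can now be read as well: (2-aminophenyl)carbamoyl in place of 2-((2-aminophenyl)carbamoyl)ethenyl on an aromatic carbon gives a number 12.1 percentage points higher from compound 2 to compound 4 (beyond the scatter), a modest step, whereas benzylamino in place of 4-methylpiperazin-1-yl on an aromatic carbon gives a number 6.1 percentage points higher from compound 1 to compound 4 (within the scatter), so those two groups cannot be told apart in this assay. Nothing measured on these compounds explains any of these steps.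

Benzyl and 4-(pyridin-2-yl)phenyl differ in several respects at once, so this one step cannot show which difference matters. A plain phenyl, a longer 2-phenylethyl chain or a small methyl on the same nitrogen would help to separate them, and would show whether benzyl is a special case or part of a broader trend.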